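Nitro on the fused ring of compound 2

The source may hold more compounds than are shown below. What is called first, only, known or untested is meant among the compounds shown, and "the series" means these compounds.

Working notes on the series. In an assay for inhibition of Amine oxidase [flavin-containing] B (Homo sapiens), read by fluorescence, using microsomes, with a stated time of 15 min (a lower number here means a stronger inhibitor, a higher number a weaker inhibitor), compound 1 `Cc1cccc(NC(=O)c2cc3ccccc3oc2=O)c1` gives 930 nM, compound 2 `O=C(Nc1cccc(C(F)(F)F)c1)c1cc2ccccc2oc1=O` gives 3300 nM, and compound 3 `Cc1ccccc1NC(=O)c1cc2cc(Br)cc(Br)c2oc1=O` gives 4680 nM. Compound 2 stands second highest of the three numbers, though the gap from compound 2 to compound 3 lies within the scatter, while a 3.5-fold higher number from compound 1 to compound 2 (0.55 log units; beyond the scatter) lies beyond it. The unmeasured compound 4 `O=C(Nc1cccc(C(F)(F)F)c1)c1cc2cc([N+](=O)[O-])ccc2oc1=O` differs from compound 2 by nitro in place of hydrogen on an aromatic carbon. Going by the values given here, no measured step bears directly on this change: the only step known, a 3.5-fold higher number from compound 1 to compound 2 (0.55 log units; beyond the scatter), concerns the amide aryl group and not the fused ring, and compound 3 carries two bromines on the fused ring together with a different amide aryl, so its value of 4680 nM cannot be split into the share of either change. With nothing pointing either way, compound 4 is expected to show no step beyond the scatter in this assay, and a 1.2-fold lower number from compound 2 to compound 4 (0.07 log units; within the scatter) is the estimated step, with a wide range. The estimate for compound 4 is 2800 nM, between 700 nM and 11000 nM.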

Compound 4, half-maximal inhibitory concentration: 22800 nM
The estimate for compound 4 lay 8.1-fold (0.91 log units) below the measured number; the measured number lies above the stated range.
By their numbers in this assay, from the lowest: compound 1; then compounds 2 and 3 (each within the scatter of the next); then compound 4.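

In this assay, nitro in place of hydrogen on an aromatic carbon of the fused system, meta to a fused ring and para to a fused ring, gives a 6.9-fold higher number from compound 2 to compound 4 (0.84 log units; beyond the scatter) with the trifluoromethyl-bearing amide aryl group held fixed. Going by these compounds alone, this is the first step that can be read on the fused ring alone, as compound 3 carries its two bromines together with a different amide aryl group. This carbon therefore does not tolerate every group equally in this assay, and nothing shown gives a reason for the step.

From the compounds shown here alone, it remains open whether the higher number is specific to nitro, as an amine or a methoxy group on the same carbon would show. Going by these compounds, it is also open whether the step carries over to compound 1, with methyl in place of trifluoromethyl.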